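The source may report more compounds than this note shows. Statements on the series, on what has been measured and on what is new or still open speak of the compounds shown alone.

Values in a functional assay on HL-60 cells (Homo sapiens) for antiproliferative activity, with a stated time of 72 h (a lower number here means a stronger inhibitor, a higher number a weaker inhibitor), for the three measured compounds:
- compound 1 `OC[C@H]1O[C@@H](n2cnc3c(NCc4ccccc4Cl)ncnc32)[C@H](O)[C@@H]1O` gives 1600 nM
- compound 2 `OC[C@H]1O[C@@H](n2cnc3c(NCc4ccc(Br)cc4)ncnc32)[C@H](O)[C@@H]1O` gives 47400 nM
- compound 3 `OC[C@H]1O[C@@H](n2cnc3c(NCc4ccc(Cl)cc4Cl)ncnc32)[C@H](O)[C@@H]1O` gives 96300 nM

Compound 2 stands in the middle of these three numbers, with only compound 3 higher. The next compound to consider is compound 4 `COc1cccc(CNc2ncnc3c2ncn3[C@@H]2O[C@H](CO)[C@@H](O)[C@H]2O)c1OC`, which has not yet been measured. It differs from compound 2 in one place: 2,3-dimethoxyphenyl in place of 4-bromophenyl on a saturated chain carbon bound to a nitrogen on an aromatic ring.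

Three measured steps change this same group. Replacing 2-chlorophenyl with 4-bromophenyl gives a large step (a 30-fold higher number from compound 1 to compound 2 (1.47 log units; beyond the scatter)). Chloro in place of hydrogen on an aromatic carbon gives an even larger one (a 60-fold higher number from compound 1 to compound 3 (1.78 log units; beyond the scatter)). Replacing 4-bromophenyl with 2,4-dichlorophenyl gives only a modest step (a 2.0-fold higher number from compound 2 to compound 3 (0.31 log units; beyond the scatter)).

Both compounds with a 4 in the group's name have high numbers, while compound 1 (1600 nM) has a 2 and no 4, as does the new group. Among the compounds with values here, that is a thin basis, and no measured compound carries a methoxy group. A moderate move to a lower number is therefore expected, with wide uncertainty. The expected step is a 3.2-fold lower number from compound 2 to compound 4 (0.50 log units; beyond the scatter). For compound 4 the estimated value is 15000 nM, with an expected range from 2500 nM to 80000 nM.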

Compound 4, half-maximal inhibitory concentration: > 166000 nM
Compound 4: a limit, no number; the forecaster's own chance of this, stated with the estimate: 15%; middle value at least 11-fold (1.04 log units) from the limit.
By their numbers in this assay, from the lowest: compound 1; then compound 2; then compound 3. At a limit, above all of these: compound 4.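

In this assay compound 4 gives only a limit, not a number: the limit of > 166000 nM in this assay, at which 1 of the 4 values shown sits.

Even so, the limit can be read as a floor, and an at least 100-fold higher number from compound 1 to compound 4 (2.01 log units; beyond the scatter) shows that a group with a 2 in its name does not by itself keep the low number of compound 1, so the 2,3-dimethoxyphenyl group goes against the pattern suggested by the earlier compounds, and an at least 3.5-fold higher number from compound 2 to compound 4 (0.54 log units; beyond the scatter) shows that this change, the first here to bring in methoxy groups and hydrogen-bond acceptors on the ring, also gives a weaker result than 4-bromophenyl. The remaining comparison is less firm: an at least 1.7-fold higher number from compound 3 to compound 4 (0.23 log units; that floor lies within the scatter), so compound 3 and compound 4 cannot be put in order.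

The compounds shown leave open whether one methoxy group alone would give the same result, as 2-methoxyphenyl and 3-methoxyphenyl would test against the 2,3-dimethoxyphenyl group. They also leave open whether the low number of compound 1 depends on chloro specifically, which 2-bromophenyl or 2-fluorophenyl on the same saturated chain carbon would address.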